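The source may report more compounds than this note shows. Statements on the series, on what has been measured and on what is new or still open speak of the compounds shown alone.

Measured in a physicochemical assay, with a stated time of 6 min; on this read-out lower numbers stand for stronger inhibition and higher numbers for weaker inhibition:
- Compound 1 `COc1ccc(NC(=O)Nc2nc(-c3cc4cc([N+](=O)[O-])ccc4o3)cs2)cc1`: 121000 nM
- Compound 2 `O=C(Nc1cccc([N+](=O)[O-])c1)Nc1nc(-c2cc3cc(Br)ccc3o2)cs1`: 159000 nM
- Compound 3 `O=C(Nc1nc(-c2cc3cc(Br)ccc3o2)cs1)Nc1ccccc1F`: > 200000 nM

The entry for compound 3 is a limit, not a number. Compound 3 stands at the limit of > 200000 nM in this assay, at which 1 of the 3 values shown sits.

Compound 4 `COc1ccc(NC(=O)Nc2nc(-c3cc4cc(Br)ccc4o3)cs2)cc1` has 4-methoxyphenyl in place of 2-fluorophenyl on an amide-type nitrogen.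

Among the compounds with values here, one measured step bears on this nitrogen: an at least 1.2-fold higher number from compound 2 to compound 3 (0.09 log units; that floor lies within the scatter). Compound 1 also carries 4-methoxyphenyl and gives 121000 nM, so this group has been seen with a measurable number.

No change beyond the scatter is therefore expected in this assay. The expected step is an at least 1.1-fold lower number from compound 3 to compound 4 (0.07 log units; that floor lies within the scatter), a small move towards a lower number. For compound 4 the estimated value is 170000 nM, with an expected range of 100000 nM to 260000 nM.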

Compound 4, half-maximal inhibitory concentration: > 200000 nM
Compound 4: a limit, no number; the forecaster's own chance of this, stated with the estimate: 40%; at least 1.1-fold (0.07 log units) between middle value and limit.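

Compound 4 gives only a limit, not a number, in this assay; with compound 3 also a limit, the step between them cannot be read. Bromo in place of nitro gives an at least 1.6-fold higher number from compound 1 to compound 4 (0.21 log units; that floor lies within the scatter), and 4-methoxyphenyl in place of 3-nitrophenyl gives an at least 1.2-fold higher number from compound 2 to compound 4 (0.09 log units; that floor lies within the scatter), so neither change is shown to go beyond the scatter. The limit of the read-out now holds more of the set: the limit of > 200000 nM in this assay, at which 2 of the 4 values shown sit.

Going by these compounds, how far compound 3 and compound 4 lie past the limit stays open, so their two nitrogen groups cannot be ranked. Also open, on these data alone, is what a hexyl chain in place of 4-methoxyphenyl on this nitrogen would give.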